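The source may hold more compounds than are shown below. What is called first, only, known or untested is meant among the compounds shown, and "the series" means these compounds.

This series of sulfonamides shares one core and varies the aromatic group on the sulfonamide nitrogen. In a functional assay on HT-29 cells (Homo sapiens) for antiproliferative activity, read by sulforhodamine B assay, with a stated time of 48 h (a higher number here means a weaker inhibitor, a lower number a stronger inhibitor), compound 1 (`CCc1ccc(NS(=O)(=O)c2ccc(N3CCNC3=O)cc2)cc1`) gives 660 nM, while compound 2 (`CCc1cccc(NS(=O)(=O)c2ccc(N3CCNC3=O)cc2)c1`) gives 110 nM. Compound 2 thus holds the lower of the two numbers and is the stronger inhibitor of this pair.

Compound 3 (`Cc1cc(C)cc(NS(=O)(=O)c2ccc(N3CCNC3=O)cc2)c1`) has not yet been measured. It carries 3,5-dimethylphenyl in place of the 3-ethylphenyl of compound 2 on a sulfonamide nitrogen: 3,5-dimethylphenyl in place of 3-ethylphenyl on a sulfonamide nitrogen. The two molecules have the same atoms, joined differently.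

Among the compounds with values here, only one measured step bears on this change: a 6.0-fold lower number from compound 1 to compound 2 (0.78 log units; beyond the scatter), a modest step in which 3-ethylphenyl replaced 4-ethylphenyl. Within the data shown here, it shows that the numbers can shift when this group is rearranged, but no measured compound carries two methyl groups, so the direction here is uncertain. With that single step as a guide, a change of similar or smaller size is expected, leaning slightly towards a higher number. The expected step is a 1.5-fold higher number from compound 2 to compound 3 (0.16 log units; within the scatter). In this assay, compound 3 is estimated at 160 nM, with an expected range of 50 nM to 500 nM.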

Compound 3, half-maximal inhibitory concentration: 82 nM
Compound 3: the middle estimate sits 2.0-fold (0.29 log units) above what was measured, and the stated range covers the measured number.
By their numbers in this assay, from the lowest: compounds 3 and 2 (each within the scatter of the next); then compound 1.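

In this assay, 3,5-dimethylphenyl in place of 3-ethylphenyl on a sulfonamide nitrogen gives a 1.3-fold lower number from compound 2 to compound 3 (0.13 log units; within the scatter), so this assay does not separate these two groups, even though one carries a single ethyl chain and the other two methyl groups. Measured against the 4-ethylphenyl group, the same 3,5-dimethylphenyl group gives an 8.0-fold lower number from compound 1 to compound 3 (0.91 log units; beyond the scatter), which means that among these three compounds, compound 1 alone stands apart, while compound 2 and compound 3 sit together at the lower numbers. Nothing measured here explains why the numbers fall this way, and no evidence on the cause is available for these compounds.

The compounds shown carry only ethyl and methyl groups on the aromatic ring, so it remains open how a single methyl group, as in 3-methylphenyl, or a longer chain such as propyl would behave at this position. Equally open, from the compounds shown here alone, is whether groups of a different kind, such as a methoxy group, a chlorine atom or an amine, would fit the picture these three compounds give.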